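Notes on the series: compound 1 and its oxazole analogue

The source may report more compounds than this note shows. Statements on the series, on what has been measured and on what is new or still open speak of the compounds shown alone.

Within the data shown here, compound 1 `Cc1cc(C)c(CN2CCc3c(Cl)cc([C@@H](CO)[C@@H]4CCOC4)c(Cl)c3C2=O)c(=O)[nH]1` gives 2910 nM in an assay on cells for inhibition of histone-lysine N-methyltransferase EZH2 (Homo sapiens), read by ELISA, with a stated time of 72 h (a lower number here means a stronger inhibitor, a higher number a weaker inhibitor), the only single number for it; two further entries gave no single figure. The other members show scattered readings: compound 2 `COC(c1cc(Cl)c2c(c1Cl)C(=O)N(Cc1c(C)cc(C)[nH]c1=O)CC2)C1CCN(C2COC2)CC1` gives 1310 nM; 16 nM (2 entries), and compound 3 `COC(c1cc(Cl)c2c(c1Cl)C(=O)N(Cc1c(C)cc(C)[nH]c1=O)CC2)C1CCN(C(C)=O)CC1` gives 2000 nM; 11 nM (2 entries), as seen in the several entries of compound 2 in this assay, 1310 nM; 16 nM (2 entries) and (the several entries of compound 3 in this assay, 2000 nM; 11 nM (2 entries)). Compound 1 stands near the weaker entries of both and well short of their stronger ones.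

Compound 4 `Cc1cc(C)c(CN2CCc3c(Cl)cc(-c4c(C)noc4C)c(Cl)c3C2=O)c(=O)[nH]1` carries the change (a group of 7 heavy atoms (5 carbon, 1 nitrogen, 1 oxygen; one five-membered aromatic ring with 2 hetero atoms) in place of a group of 8 heavy atoms (6 carbon, 2 oxygen; one five-membered non-aromatic ring with 1 hetero atom), on an aromatic carbon), on an aromatic carbon ortho to one chloro group and meta to the other. Among the measured compounds shown here, no measured pair isolates this change, so a step of modest size, in either direction or none beyond the scatter, is expected in this assay. Compound 4 is therefore estimated at 4000 nM, range 1000 nM to 15000 nM, which means an expected step of a 1.4-fold higher number from compound 1 to compound 4 (0.14 log units; within the scatter).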

Compound 4, half-maximal inhibitory concentration: 17 nM
Beside the measured number, compound 4's estimate is 240-fold (2.37 log units) above it; measured number below the stated range.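

At this aromatic carbon, ortho to a chloro group, 3,5-dimethyl-1,2-oxazol-4-yl in place of the group with the non-aromatic five-membered ring gives a 170-fold lower number from compound 1 to compound 4 (2.23 log units; beyond the scatter), so the number depends strongly on the group held here. Single readings in this assay need care, since entries for one compound can lie far apart: the several entries of compound 2 in this assay, 1310 nM; 16 nM (2 entries). The same spread appears again: the several entries of compound 3 in this assay, 2000 nM; 11 nM (2 entries).

The compounds shown leave open whether the step belongs to the aromatic ring or to its two methyl groups. A phenyl ring or an unsubstituted 1,2-oxazol-4-yl at this carbon would separate the two.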